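Swapping the Acyl Group on a Shared Sulfonate Ester Core

The compounds below may be only part of what the source reports. "The series", "measured", "known", "first", "only" and "open" are said of these compounds alone.

Compound 1 `CC(C)c1ccccc1OS(=O)(=O)c1cccc(NC(=O)C(C)(C)C)c1`: 11000 nM
Compound 2 `CC(C)c1ccccc1OS(=O)(=O)c1cccc(NC(=O)CCl)c1`: 780 nM
Compound 3 `CC(C)c1ccccc1OS(=O)(=O)c1ccc(NC(=O)C(C)(C)C)cc1`: 11000 nM

These values come from a functional assay on HT-1080 cells (Homo sapiens) for antiproliferative activity, read by sulforhodamine B assay, with a stated time of 48 h; a higher number here means a weaker inhibitor, a lower number a stronger inhibitor. Compound 1 and compound 3 contain the same atoms joined differently; the difference between the two cores is not broken down here, and in this assay their numbers are level. Compound 2 is compound 1 with chloromethyl in place of tert-butyl on a carbonyl carbon, and that change gives a 14-fold lower number from compound 1 to compound 2 (1.15 log units; beyond the scatter). Compound 4 `CC(C)c1ccccc1OS(=O)(=O)c1ccc(NC(=O)CCl)cc1` is compound 3 with the same change, (chloromethyl in place of tert-butyl on a carbonyl carbon), at a place described in identical words. Since compound 1 and compound 3 give matching numbers, a step of similar size is expected here because a 14-fold lower number from compound 1 to compound 2 (1.15 log units; beyond the scatter). The expected step is a 14-fold lower number from compound 3 to compound 4 (1.14 log units; beyond the scatter). Compound 4 is therefore estimated at 800 nM, within a range from 300 nM to 2500 nM.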

Compound 4, half-maximal inhibitory concentration: 1000 nM
Beside the measured number, compound 4's estimate is 1.3-fold (0.10 log units) below it; the range from low to high includes it.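

In this assay putting chloromethyl in place of tert-butyl on a carbonyl carbon gives an 11-fold lower number from compound 3 to compound 4 (1.04 log units; beyond the scatter) on this second core. The change therefore carries over between these two cores, and by a matching amount: the same change on two cores in this assay, a 14-fold lower number (1.15 log units; beyond the scatter) from compound 1 to compound 2 and an 11-fold lower number (1.04 log units; beyond the scatter) from compound 3 to compound 4, 1.3-fold (0.11 log units) apart, within the scatter of two such steps. Among these compounds, this rests on only two pairs of compounds in a single cell assay, so it does not show that the change would do the same on any other core, nor does it explain why the number falls.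

The compounds shown leave open how other groups on this carbonyl carbon would compare, such as bromomethyl, a plain methyl or a longer chain. They also leave open whether the rest of the molecule affects the size of the step.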